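A few compounds are considered here, and "the series" means these few. Any claim that something is new, unique, unknown or untested is made for them only; others in the source may bear on it.

- Compound 1 `C[C@]1(C(=O)N2CC[C@](c3ccc(C(F)(C(F)(F)F)C(F)(F)F)cc3)(S(=O)(=O)c3ccc(F)cc3)C2)CC[C@H](C(=O)O)CC1`: 80%
- Compound 2 `O=C([C@H]1CC[C@H](c2nnn[nH]2)CC1)N1CC[C@](c2ccc(C(F)(C(F)(F)F)C(F)(F)F)cc2)(S(=O)(=O)c2ccc(F)cc2)C1`: 100%

Among the compounds with values here, in an ADME assay on microsomes from liver (Homo sapiens) for metabolic stability, with a stated time of 10 min (a higher number here means that more of the compound is left, a lower number that less of the compound is left), compound 2 gives 100%, the higher of the two numbers so far. Compound 3 `O=C([C@H]1CC[C@H](CO)CC1)N1CC[C@](c2ccc(C(F)(C(F)(F)F)C(F)(F)F)cc2)(S(=O)(=O)c2ccc(F)cc2)C1` differs from compound 2 in one place: hydroxymethyl in place of 1H-tetrazol-5-yl on a saturated ring carbon. In words, this is hydroxymethyl in place of 1H-tetrazol-5-yl on a saturated ring carbon. Within the data shown here, only one measured step bears on this change, and it is a modest one: a number 20 percentage points higher from compound 1 to compound 2 (beyond the scatter). That step brought in the 4-(1H-tetrazol-5-yl)cyclohexyl group, which compound 3 gives up for 4-(hydroxymethyl)cyclohexyl. With compound 2 at 100%, this read-out leaves little room for a further rise, so a modest fall is the likelier outcome. The expected change is a number 20 percentage points lower from compound 2 to compound 3 (beyond the scatter). The estimate for compound 3 is 80%, with an expected range from 60% to 100%.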

Compound 3, percent of the compound remaining: 75%
For compound 3 the middle estimate is 5 percentage points above the measured one; the range from low to high includes it.
By their numbers in this assay, from the lowest: compounds 3 and 1 (each within the scatter of the next); then compound 2.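

In this assay, putting hydroxymethyl in place of 1H-tetrazol-5-yl on this saturated ring carbon gives a number 25 percentage points lower from compound 2 to compound 3 (beyond the scatter), so the group held here does affect how much compound is left. The other new comparison gives a number 5 percentage points lower from compound 1 to compound 3 (within the scatter), so 4-(hydroxymethyl)cyclohexyl and 4-carboxy-1-methylcyclohexyl cannot be told apart in this read-out, and only the tetrazole-bearing compound 2 stands apart from both. Nothing available explains these differences.

Compound 1 differs from compound 2 in both its carboxylic acid and its ring methyl group, so the contribution of each remains unresolved. A 4-carboxycyclohexyl group without the methyl would separate the two, while an aminomethyl group at this ring carbon would show how a basic amine compares with hydroxymethyl.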